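This account rests on a few compounds, and the source may have more. Where it says the series, first, only, none or still open, it means among the compounds named here.

Measured in a functional assay on HeLa cells (Homo sapiens) for inhibition, read by CCK-8 assay, with a stated time of 48 h; on this read-out lower numbers stand for stronger inhibition and higher numbers for weaker inhibition:
Compound 1 `COc1cc(-c2cc3nccc(-c4cc(OC)c(OC)c(OC)c4)n3n2)cc(OC)c1OC`: > 10000 nM (a limit)
Compound 2 `COc1cc(-c2ccnc3cc(-c4ccc(F)cc4)nn23)cc(OC)c1OC`: 5840 nM
Compound 3 `COc1cc(-c2cc3nccc(-c4c[nH]c5ccccc45)n3n2)cc(OC)c1OC`: > 10000 nM (a limit)

Of these three, only compound 2 gives an actual number, at 5840 nM. Compound 1 and compound 3 both sit at the limit of > 10000 nM in this assay, at which 2 of the 3 values shown sit, and that figure is a limit of this assay, not a measured number. Compound 2 therefore has no numerical neighbour to be ranked against.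

The next compound to be tested is compound 4 `COc1cc(-c2ccnc3cc(-c4ccc(Cl)cc4)nn23)cc(OC)c1OC`. It keeps the shared core of compound 2 and changes a single substituent, with chloro in place of fluoro on an aromatic carbon, so that 4-fluorophenyl becomes 4-chlorophenyl: chloro in place of fluoro on an aromatic carbon. The exchange sits on a six-membered aromatic ring of carbon only, para to a large group.

Within the data shown here, no measured pair in this set differs in only one place, so the data offer no direct guide to the size of such a change in this assay. With so small a substitution, no shift beyond the usual scatter is expected, and no direction is favoured. The estimated step of a 1.1-fold lower number from compound 2 to compound 4 (0.03 log units; within the scatter) is expected to stay within that scatter, starting from compound 2 at 5840 nM. For compound 4 the expected value is 5500 nM, with an estimated range of 2000 nM to 10000 nM.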

Compound 4, half-maximal inhibitory concentration: 1490 nM
For compound 4 the middle estimate is 3.7-fold (0.57 log units) above the measured one; the measured number lies below the stated range.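

In this assay, among these compounds, moving from 4-fluorophenyl to 4-chlorophenyl gives a 3.9-fold lower number from compound 2 to compound 4 (0.59 log units; beyond the scatter) and is the first change in the set that can be read in one place. It shows that this position, on an aromatic carbon of a six-membered aromatic ring of carbon only and para to a large group, is not indifferent to which halogen it carries, even though one heavy atom is simply exchanged for another and the count of hydrogen-bond donors and acceptors stays the same. The result rests on this single pair, and nothing measured for these compounds accounts for the size or direction of the step.

The compounds shown leave open whether the trend from fluoro to chloro would continue with bromo or iodo, and whether a methyl, a methoxy, an amine or a carboxylic acid on the same carbon would lower the number further or raise it. They also leave open whether chloro would have the same effect with other groups elsewhere on the shared core.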